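Swapping the Amide Cap: Clearance Outlook for Compound 3

The source may hold more compounds than are shown below. What is called first, only, known or untested is meant among the compounds shown, and "the series" means these compounds.

Two close relatives sharing one core have been run through an in vivo ADME assay on the whole organism (Rattus norvegicus) for pharmacokinetics; on this read-out lower numbers stand for slow clearance and higher numbers for fast clearance. Compound 1 `CCCC[C@H](NC(=O)O[C@H](Cn1cnc(-c2ccc(C(F)(F)F)cc2)c1)C(C)(C)C)C(=O)C(=O)Nc1ccn[nH]1` gives 15 mL/min/kg there. Compound 2 `CCCC[C@H](NC(=O)O[C@H](Cn1ccc(-c2ccc(C(F)(F)F)cc2)n1)C(C)(C)C)C(=O)C(=O)Nc1ccccn1` gives 41 mL/min/kg in this assay, the higher of the two numbers, and that gap lies beyond the usual scatter. Compound 3 `CCCC[C@H](NC(=O)O[C@H](Cn1ccc(-c2ccc(C(F)(F)F)cc2)n1)C(C)(C)C)C(=O)C(=O)NCc1ccno1` is built from compound 2 by a single change: (1,2-oxazol-5-yl)methyl in place of pyridin-2-yl on an amide-type nitrogen. Going by the values given here, no measured pair shows this exact swap, so nothing fixes its size. The expected step from compound 2 to compound 3 is a 1.2-fold lower number from compound 2 to compound 3 (0.07 log units; within the scatter), essentially none beyond the scatter. Compound 3 is accordingly estimated at 35 mL/min/kg, somewhere between 15 mL/min/kg and 80 mL/min/kg.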

Compound 3, clearance: 3.2 mL/min/kg
Beside the measured number, compound 3's estimate is 11-fold (1.04 log units) above it, and the stated range ends above it.
By their numbers in this assay, from the lowest: compound 3; then compound 1; then compound 2.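

This amide-type nitrogen proves to be a highly sensitive position in this assay: (1,2-oxazol-5-yl)methyl in place of pyridin-2-yl gives a 13-fold lower number from compound 2 to compound 3 (1.11 log units; beyond the scatter), a large step. The earlier compounds shown here differ in more than one place, so they could not isolate the effect of this position. No available evidence gives a cause for this step.

The change alters both the ring and the link to the nitrogen, so the compounds shown cannot separate these two contributions. A (pyridin-2-yl)methyl group at this position would keep the pyridine ring while adding the one-carbon link.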